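Pyrazole Attachment Point and Maximal Response

The source may hold more compounds than are shown below. What is called first, only, known or untested is meant among the compounds shown, and "the series" means these compounds.

Compound 2, with structure `Cn1ncnc1-c1ccccc1NCC1=NCCN1`, stands highest of the two measured compounds in a functional assay with Alpha-1A adrenergic receptor (Homo sapiens) as the target, read by calcium flux; a higher number here means a larger maximal response, a lower number a smaller maximal response: compound 2 gives 91%. For the measured compounds named here, its nearest neighbour is compound 1, with structure `Cn1cc(-c2ccccc2NCC2=NCCN2)cn1`, which in this assay gives 39%; the single measured step is a number 52 percentage points higher from compound 1 to compound 2 (beyond the scatter). Compound 3, with structure `Cn1ccc(-c2ccccc2NCC2=NCCN2)n1`, has not yet been measured. It differs from compound 2 in one place: 1-methyl-1H-pyrazol-3-yl in place of 1-methyl-1H-1,2,4-triazol-5-yl on an aromatic carbon. Going by the values given here, the only step that bears on this change is the one from compound 1 to compound 2, in which a 1-methyl-1H-pyrazol-4-yl gave way to a 1-methyl-1H-1,2,4-triazol-5-yl and the maximal response rose greatly. Compound 3 reverses that exchange in part, returning to a pyrazole but attached at a different ring carbon, so the step is expected to run downward, though not necessarily all the way back to compound 1. For compound 3 in this assay a value of 65% is expected, within a range of 35% to 95%, which amounts to an expected step of a number 26 percentage points lower from compound 2 to compound 3 (beyond the scatter).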

Compound 3, largest response reached (reported as maximal response), in percent of the reference or control that the assay uses: 116%
Compound 3: the middle estimate sits 51 percentage points below what was measured; measured number outside the range, above it.
By their numbers in this assay, from the lowest: compound 1; then compound 2; then compound 3.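

In this assay, the exchange of one methylpyrazole for another brings a number 77 percentage points higher from compound 1 to compound 3 (beyond the scatter) and so separates 1-methyl-1H-pyrazol-4-yl from 1-methyl-1H-pyrazol-3-yl by a large margin, although the two differ only in the ring carbon that joins them to the shared core. The further rise, a number 25 percentage points higher from compound 2 to compound 3 (beyond the scatter), shows that the high maximal response of compound 2 does not depend on a ring with 3 hetero atoms, since the 1-methyl-1H-pyrazol-3-yl with 2 hetero atoms in the same place goes beyond the 1-methyl-1H-1,2,4-triazol-5-yl. No measurement at hand accounts for the way this position responds.

The compounds shown leave open whether the response holds when the methyl on the pyrazole gives way to an ethyl or to a plain hydrogen, or when an amine or a carboxylic acid is added to the ring. They also leave open how a 1-methyl-1H-pyrazol-5-yl, the remaining attachment of this methylpyrazole, would fall among the three numbers.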